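The compounds below may be only part of what the source reports. "The series", "measured", "known", "first", "only" and "open" are said of these compounds alone.

Three compounds have been measured in an in vitro functional assay on HEK285-7 cells for antagonist activity at prostaglandin D2 receptor 2 (Homo sapiens), read by BRET and beta-arrestin recruitment; on this read-out higher numbers stand for weaker inhibition and lower numbers for stronger inhibition:

Compound 1 `Cc1nc(-c2ccc(Cl)cc2)c(CC(=O)O)s1`: 41000 nM
Compound 2 `Nc1nc(-c2ccc(Cl)cc2)c(CC(=O)O)s1`, which sits at a limit of the assay rather than at a number: > 100000 nM
Compound 3 `O=C(O)Cc1sc(C(c2ccc(F)cc2)c2ccc(F)cc2)nc1-c1ccnc(F)c1`: 4.7 nM

Of the two numbers, compound 3 gives the lower one, and so the stronger inhibition; compound 1 gives a far higher number. Among the measured compounds shown here, the only step between measured compounds that differ in one place is an at least 2.4-fold higher number from compound 1 to compound 2 (0.38 log units; beyond the scatter).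

Compound 4 `O=C(O)Cc1sc(C(c2ccc(F)cc2)c2ccc(F)cc2)nc1-c1ccncc1` differs from compound 3 in one place: hydrogen in place of fluoro on an aromatic carbon. The group that leaves is a fluoro on an aromatic carbon of a six-membered aromatic ring with one nitrogen, next to the ring nitrogen; the whole piece changes from 2-fluoropyridin-4-yl to pyridin-4-yl.

For the measured compounds named here, no measured step matches this change. Going by the values given here, the one step on record swaps a methyl for an amino on the shared core of compound 1, a different group on a different ring, so it gives little guidance here. Removing a single fluoro is a small change, and compound 3 already sits at a low number. The expected step is therefore a 2.1-fold higher number from compound 3 to compound 4 (0.33 log units; beyond the scatter), a shift of small size, most likely towards a somewhat higher number. Compound 4 is expected to give 10 nM in this assay, within a range from 3 nM to 40 nM.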

Compound 4, half-maximal inhibitory concentration: 40 nM
For compound 4 the middle estimate is 4.0-fold (0.60 log units) below the measured one; the measured number falls inside the stated range.
By their numbers in this assay, from the lowest: compound 3; then compound 4; then compound 1. At a limit, above all of these: compound 2.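

In this assay the fluoro of the 2-fluoropyridin-4-yl group in compound 3 proves to count for more than its size might suggest: replacing it with hydrogen to leave pyridin-4-yl gives a clear change (an 8.5-fold higher number from compound 3 to compound 4 (0.93 log units; beyond the scatter)). Among the compounds shown here, this is the first measured step at this place, an aromatic carbon next to the ring nitrogen, and it shows that a swap of one heavy atom there moves the number beyond the usual scatter; the earlier step, amino in place of methyl on the core of compound 1, lies elsewhere and could not show this. Nothing shown here explains why this single atom makes such a difference.

The compounds shown carry only hydrogen or fluoro at this carbon, so they leave open what a chloro, a methyl or a methoxy group there would give. They also leave open whether the same swap of fluoro for hydrogen would produce a step of similar size on the core of compound 1, where the rest of the molecule is different.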